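Benzoyl for benzothiophenyl on the thioether arm

This account rests on a few compounds, and the source may have more. Where it says the series, first, only, none or still open, it means among the compounds named here.

Measured so far:
Compound 1, `Cc1cc(Nc2cc(-c3ccccc3)[nH]n2)n2nc(SCc3csc4ccccc34)nc2n1`: 29200 nM
Compound 2, `Cc1cc(Nc2ccn(Cc3nc(C)c4ccccc4n3)n2)n2nc(SCc3ccc(Br)cc3)nc2n1`: 36800 nM
Compound 3, `Cc1ccc(Cn2ccc(Nc3cc(C)nc4nc(SCc5ccc(Br)cc5)nn34)n2)cc1`: > 50000 nM

In an ADME assay on GES1 cells (Homo sapiens) for inhibition, read by MTT assay, with a stated time of 72 h (a lower number here means a stronger inhibitor, a higher number a weaker inhibitor), compound 1 gives 29200 nM, the lowest of the two plain numbers shown. Its nearest neighbour is compound 2, which in this assay gives 36800 nM, a gap that lies within the scatter of repeated measurements, so the two cannot be placed in order. For compound 3 this assay reports only a limit, > 50000 nM. Going by the values given here, the one step between measured compounds that differ in a single place is an at least 1.3-fold higher number from compound 2 to compound 3 (0.13 log units; that floor lies within the scatter); it changes the group on a saturated chain carbon bound to an aromatic nitrogen and touches the shared core at a different arm, so it does not bear on the change examined here.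

Compound 4, `Cc1cc(Nc2cc(-c3ccccc3)[nH]n2)n2nc(SCC(=O)c3ccccc3)nc2n1`, differs from compound 1 as follows: benzoyl in place of 1-benzothiophen-3-yl on a saturated chain carbon bound to a sulfur. Nothing measured speaks to the thioether arm. Given that the one step seen, and the gap between compound 1 and compound 2, stay within the scatter, the expected step of a 1.0-fold higher number from compound 1 to compound 4 (0.01 log units; within the scatter) is none beyond the scatter. Compound 4 is therefore estimated at 30000 nM, with a range from 12000 nM to 75000 nM.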

Compound 4, half-maximal inhibitory concentration: 33300 nM
Compound 4: the middle estimate sits 1.1-fold (0.05 log units) below what was measured; low and high end bracket the measured number.
By their numbers in this assay, from the lowest: compounds 1, 4 and 2 (each within the scatter of the next). At a limit, above all of these: compound 3.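

The change from 1-benzothiophen-3-yl to benzoyl, on a saturated chain carbon bound to a sulfur, gives in this assay a 1.1-fold higher number from compound 1 to compound 4 (0.06 log units; within the scatter). Going by these compounds alone, this is the first reading at the thioether arm, and it shows that a group with a five-membered aromatic ring and a six-membered aromatic ring can give way to one with a single six-membered aromatic ring and a carbonyl without a step beyond the scatter, so the two compounds cannot be placed in order. Compound 3, which differs at other places too, remains the only compound at a limit of the assay, and that limit is no number to set against this pair: the limit of > 50000 nM in this assay, at which 1 of the 4 values shown sits.

As far as these compounds go, whether an amine or a carboxylic acid on the benzoyl ring, or a longer chain on the sulfur, would give a step beyond the scatter in this assay stays open. Also open, from the compounds shown here alone, is whether benzoyl would read the same way in compounds carrying the 4-methylquinazolin-2-yl or 4-methylphenyl groups, whose thioether arm holds a different group.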